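Selenium Gives Way to Sulfur: Expecting Compound 3

This account rests on a few compounds, and the source may have more. Where it says the series, first, only, none or still open, it means among the compounds named here.

Of the compounds shown here, two sharing one fused aromatic core have been tested in a functional assay on CCRF-CEM cells (Homo sapiens) for cytotoxicity, read by sulforhodamine B assay, with a stated time of 72 h; on this read-out lower numbers stand for stronger inhibition and higher numbers for weaker inhibition. Compound 1, `OCC#CCSc1cnc2ccccc2c1SCC#CCO`, carries two identical chains and gives 2.6 ug/mL. Compound 2, `CSc1cnc2ccccc2c1[Se]CC#CCO`, keeps a methylsulfanyl group on one side and a selenium-containing chain on the other, and gives 0.5 ug/mL. Of the two numbers, compound 2 has the lower one, and the gap to compound 1 is beyond the usual scatter of this assay, so compound 2 is the stronger of the pair.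

The next compound, compound 3, `CSc1cnc2ccccc2c1SCC#CCO`, has not yet been measured. It differs from compound 2 in one place: a group of 6 heavy atoms (4 carbon, 1 oxygen, 1 sulfur; no ring) in place of a group of 6 heavy atoms (4 carbon, 1 oxygen, 1 selenium; no ring), on an aromatic carbon. The change therefore puts a sulfur where selenium stood, on the aromatic carbon ortho to the methylsulfanyl group.

For the measured compounds named here, no step between measured compounds shows what this exchange does, so the expectation rests on the two values alone. A modest loss of potency is expected for compound 3, a step of a 2.4-fold higher number from compound 2 to compound 3 (0.38 log units; beyond the scatter), landing it between the two measured values. Compound 3 is estimated at 1.2 ug/mL, with a likely range from 0.4 ug/mL to 3.5 ug/mL.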

Compound 3, concentration for 50% inhibition: 2.3 ug/mL
Beside the measured number, compound 3's estimate is 1.9-fold (0.28 log units) below it, within the range that was stated.
By their numbers in this assay, from the lowest: compound 2; then compounds 3 and 1 (each within the scatter of the next).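

In this assay the exchange of selenium for sulfur on this aromatic carbon, opposite the ring nitrogen and ortho to a methylsulfanyl group, now has a measured size: a 4.6-fold higher number from compound 2 to compound 3 (0.66 log units; beyond the scatter). With sulfur in this place, compound 3 no longer stands apart from compound 1, so the lead that compound 2 held over compound 1 goes with the selenium atom, as far as these three compounds show. The second new step, a 1.1-fold lower number from compound 1 to compound 3 (0.05 log units; within the scatter), puts hydrogen in place of 3-hydroxyprop-1-yn-1-yl on a saturated chain carbon bound to a sulfur, and since it stays within the scatter, this read-out does not separate the longer chain of compound 1 from the methylsulfanyl group of compound 3, while nothing measured here accounts for the gap between selenium and sulfur.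

The compounds shown leave open whether an oxygen atom in that same place, linking the chain to the aromatic carbon, would fall nearer to selenium or to sulfur. They also leave open whether selenium would keep its lead with a longer chain, or an amine, in place of the methylsulfanyl group.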